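Swapping Pyridin-3-yl for Thiophen-2-yl on a Saturated Ring Carbon

The source may hold more compounds than are shown below. What is called first, only, known or untested is meant among the compounds shown, and "the series" means these compounds.

Compound 3 `O=C(O)CC/C=C\CC1COC(c2cccnc2)OC1c1cccnc1` carries a pyridin-3-yl group on a saturated ring carbon of the shared core. In an assay for inhibition of Thromboxane-A synthase (Homo sapiens), using microsomes (a higher number here means a weaker inhibitor, a lower number a stronger inhibitor), compound 3 gives 220 nM, the highest number among the three measured compounds. Compound 1 `N#Cc1ccccc1C1OCC(C/C=C\CCC(=O)O)C(c2cccnc2)O1` gives 54 nM in this assay, and compound 2 `O=C(O)CC/C=C\CC1COC(c2ccc(Cl)cc2Cl)OC1c1cccnc1` gives 42 nM; the step of a 1.3-fold lower number from compound 1 to compound 2 (0.11 log units; within the scatter) lies within the scatter. Both steps that end at compound 3 are beyond the scatter: a 4.1-fold higher number from compound 1 to compound 3 (0.61 log units; beyond the scatter) and a 5.2-fold higher number from compound 2 to compound 3 (0.72 log units; beyond the scatter).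

Compound 4 `O=C(O)CC/C=C\CC1COC(c2cccs2)OC1c1cccnc1` differs from compound 3 in one place: thiophen-2-yl in place of pyridin-3-yl on a saturated ring carbon. The steps from compound 1 and compound 2 to compound 3 bear on this change, since each of them replaced a group without a ring nitrogen by pyridin-3-yl on the same saturated ring carbon and raised the number by a modest amount. Thiophen-2-yl was not among the groups measured, so the step of a 2.8-fold lower number from compound 3 to compound 4 (0.44 log units; beyond the scatter) is expected to be a modest lowering in this assay, but with wide uncertainty. Compound 4 is therefore estimated at 80 nM, with a range from 30 nM to 250 nM.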

Compound 4, half-maximal inhibitory concentration: 71 nM
The estimate for compound 4 lay 1.1-fold (0.05 log units) above the measured number; measured number inside the range.
By their numbers in this assay, from the lowest: compounds 2, 1 and 4 (each within the scatter of the next); then compound 3.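

For the compounds shown here, the earlier compounds showed only that pyridin-3-yl raised the number relative to two substituted phenyl groups; thiophen-2-yl shows that a five-membered aromatic ring with sulfur as its hetero atom does not share that effect at this carbon between two ring oxygen atoms. In this assay the change gives a 3.1-fold lower number from compound 3 to compound 4 (0.49 log units; beyond the scatter), and compound 3 now stands apart from all three other compounds. The remaining steps, a 1.7-fold higher number from compound 2 to compound 4 (0.23 log units; within the scatter) and a 1.3-fold higher number from compound 1 to compound 4 (0.12 log units; within the scatter), both lie within the scatter, so thiophen-2-yl cannot be separated from the 2,4-dichlorophenyl or 2-cyanophenyl groups here.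

Nothing available explains why pyridin-3-yl stands apart. The compounds shown also leave open where an unsubstituted phenyl, a furan-2-yl or a pyridin-4-yl group would fall at this carbon, and so whether the ring nitrogen itself matters.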